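The source may hold more compounds than are shown below. What is called first, only, known or untested is meant among the compounds shown, and "the series" means these compounds.

Of the compounds shown here, three sharing one core have been tested in a functional assay on A-431 cells (Homo sapiens) for antiproliferative activity, read by MTT assay, with a stated time of 72 h; on this read-out higher numbers stand for weaker inhibition and lower numbers for stronger inhibition. Compound 1 `CN1CCN(Cc2ccc(NC(=O)Nc3ccc4ncnc(Nc5ccc(F)c(F)c5)c4c3)cc2)CC1` gives > 10000 nM, which is a limit of the assay rather than a number. Compound 2 `CN1CCN(Cc2ccc(NC(=O)Nc3ccc4ncnc(Nc5cccc(C(=O)N6CCCC6)c5)c4c3)cc2)CC1` likewise gives > 10000 nM, again a limit. Going by the values given here, compound 3 `O=C(Nc1ccc(CN2CCCC2)cc1)Nc1ccc2ncnc(Nc3cccc(C(F)(F)F)c3)c2c1` is the one member with a measured number: in this assay compound 3 gives 1360 nM. It stands alone on the scale, with the other two sitting at the limit of > 10000 nM in this assay, at which 2 of the 3 values shown sit. Compound 4 `CN1CCN(c2ccc(NC(=O)Nc3ccc4ncnc(Nc5cccc(C(F)(F)F)c5)c4c3)cc2)CC1` has not yet been tested. It differs from compound 3 in one place: 4-methylpiperazin-1-yl in place of (pyrrolidin-1-yl)methyl on an aromatic carbon. Among the compounds with values here, no measured pair isolates this change, and no size can be read from the data. The two compounds that sit at the limit are the nearest relatives of compound 4 in that region of the molecule. The step of a 2.2-fold higher number from compound 3 to compound 4 (0.34 log units; beyond the scatter) is expected to be a modest loss, near the edge of the scatter. Compound 4 is therefore estimated at 3000 nM, within 800 nM to 15000 nM, with a fair chance that only a limit is reported.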

Compound 4, half-maximal inhibitory concentration: 2200 nM
For compound 4 the middle estimate is 1.4-fold (0.13 log units) above the measured one; the measured number falls inside the stated range.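

In this assay, the exchange of (pyrrolidin-1-yl)methyl for 4-methylpiperazin-1-yl on this aromatic carbon gives a 1.6-fold higher number from compound 3 to compound 4 (0.21 log units; within the scatter), so the two compounds cannot be told apart. This single pair shows that this position, para to a large group, accepts a ring attached directly as well as one attached through a carbon, with a second ring nitrogen present and no clear change in the read-out. Compound 1 and compound 2 each remain at a limit of the assay, not a number, and each differs from compound 4 in more than one place, so those comparisons cannot be read: the limit of > 10000 nM in this assay, at which 2 of the 4 values shown sit.

Going by these compounds, it remains open whether a morpholin-4-yl ring, a simple dimethylamino group or a carboxylic acid would fit this position equally well. The compounds shown also leave open whether the same exchange gives the same result with something other than trifluoromethyl at the far end of the molecule.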